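Moving a trifluoromethyl to the para position of the aryl group

The source may hold more compounds than are shown below. What is called first, only, known or untested is meant among the compounds shown, and "the series" means these compounds.

Two analogues sharing one core have so far been measured in an assay on membranes from liver for displacement of a labelled ligand from Glucagon receptor (Mus musculus), read by scintillation counting, with a stated time of 60 min; a lower number here means a stronger inhibitor, a higher number a weaker inhibitor. Compound 1, `CC(C)(C)CC[C@H](c1ccc(C(=O)NCc2nn[nH]n2)cc1)N1C(=O)C(c2cccc(C(F)(F)F)c2)=N[C@]12CC[C@@H](C(C)(C)C)CC2`, gives 140 nM in this assay. Compound 2, `CC(C)(C)CC[C@H](c1ccc(C(=O)NCc2nn[nH]n2)cc1)N1C(=O)C(c2ccc(F)cc2)=N[C@]12CC[C@@H](C(C)(C)C)CC2`, gives 90 nM in this assay. For the measured compounds named here, compound 2 therefore holds the lowest of the two numbers, but its only neighbour is compound 1, and the step of a 1.6-fold lower number from compound 1 to compound 2 (0.19 log units; within the scatter) keeps the pair inside the usual scatter, so no order can be read between them.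

The next compound, compound 3, is `CC(C)(C)CC[C@H](c1ccc(C(=O)NCc2nn[nH]n2)cc1)N1C(=O)C(c2ccc(C(F)(F)F)cc2)=N[C@]12CC[C@@H](C(C)(C)C)CC2`. Relative to compound 2 the change is trifluoromethyl in place of fluoro on an aromatic carbon. Going by the values given here, only one measured step bears on this: a 1.6-fold lower number from compound 1 to compound 2 (0.19 log units; within the scatter), which exchanged a 3-(trifluoromethyl)phenyl for a 4-fluorophenyl without leaving the scatter. Placing the trifluoromethyl on the aromatic carbon para to the large group is a related but not identical change, and nothing measured separates the two ring substituents in either direction.

The account therefore expects no step beyond the scatter, a 1.2-fold higher number from compound 2 to compound 3 (0.09 log units; within the scatter), and estimates compound 3 at 110 nM with a range of 45 nM to 270 nM in this assay.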

Compound 3, half-maximal inhibitory concentration: 190 nM
For compound 3 the middle estimate is 1.7-fold (0.24 log units) below the measured one; the range from low to high includes it.
By their numbers in this assay, from the lowest: compounds 2, 1 and 3 (each within the scatter of the next, the first and the last beyond it).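

In this assay, trifluoromethyl in place of fluoro on an aromatic carbon para to a large group gives a 2.1-fold higher number from compound 2 to compound 3 (0.32 log units; beyond the scatter), the only step among these compounds that lies beyond the scatter, and it is a modest one. The change from 3-(trifluoromethyl)phenyl to 4-(trifluoromethyl)phenyl gives a 1.4-fold higher number from compound 1 to compound 3 (0.13 log units; within the scatter), so these compounds do not separate the two placements of the trifluoromethyl group. The aryl substituent can therefore shift the number a little, but only between compound 2 and compound 3, since compound 1 stays within the scatter of both, and nothing measured on these compounds accounts for the step.

The compounds shown leave open how a chloro, a methoxy or a nitrile on the same aromatic carbon would stand against fluoro and trifluoromethyl, and whether a plain phenyl with no substituent would read differently from all of them. They also leave open whether a step of this size between fluoro and trifluoromethyl would recur with a different group in place of the tert-butyl on the shared core.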